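The compounds below may be only part of what the source reports. "The series", "measured", "known", "first", "only" and "open" are said of these compounds alone.

Compound 1, `CCc1cc2ccccc2nc1-c1cc(-c2ccccc2)no1`: in a functional assay on MDA-MB-231 cells (Homo sapiens) for inhibition, read by MTT assay, with a stated time of 24 h (on this read-out lower numbers stand for stronger inhibition and higher numbers for weaker inhibition), compound 1 gives > 100000 nM, a limit of the assay rather than a number.
Compound 2, `CCCc1cc2ccccc2nc1-c1cc(-c2ccccc2)no1`: in this assay compound 2 gives 47200 nM.

Compound 2 thus holds the only number shown in this assay; the one further value shown is a limit, (the limit of > 100000 nM in this assay, at which 1 of the 2 values shown sits). Going by the values given here, the single measured step, an at least 2.1-fold lower number from compound 1 to compound 2 (0.32 log units; beyond the scatter), runs from that limit to the number of compound 2, so its true size is known only as a lower bound.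

Compound 3, `CCCCc1cc2ccccc2nc1-c1cc(-c2ccccc2)no1`, is not yet measured. It differs from compound 2 by methyl in place of hydrogen on a saturated chain carbon, three bonds along the chain from an aromatic carbon. The measured step bears on it directly: it is the same kind of change, a methyl added to the chain, made one bond further out. On that evidence a further lowering of the number in this assay is plausible, though nothing shows whether the second addition carries as much as the first.

The account therefore expects for compound 3 a step of a 1.9-fold lower number from compound 2 to compound 3 (0.28 log units; within the scatter), a modest lowering. Compound 3 is expected to give an estimate of 25000 nM in this assay, within a range from 8000 nM to 80000 nM.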

Compound 3, half-maximal inhibitory concentration: > 100000 nM
Compound 3: a limit, no number; the forecaster's own chance of this, stated with the estimate: 10%; middle value at least 4.0-fold (0.60 log units) away from the limit.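

Adding a methyl three bonds along the chain does not continue the lowering seen one bond closer in, since the step from propyl to butyl reverses its direction, giving an at least 2.1-fold higher number from compound 2 to compound 3 (0.32 log units; beyond the scatter). Compound 3 gives > 100000 nM, which is a limit of the assay and not a number. The same change therefore does not act in the same direction at these two places on the chain, and among the ethyl, propyl and butyl compounds, only the propyl chain of compound 2 yields a number in this assay: the limit of > 100000 nM in this assay, at which 2 of the 3 values shown sit.

From the compounds shown here alone, the step between compound 1 and compound 3 joins two limits and cannot be read, so how far the ethyl and butyl compounds lie beyond the limit, and how large the rise and fall around compound 2 really are, stays open. Also open, going by these compounds, is whether any other group at this place would give a number in this assay, such as a longer pentyl chain, a branched isopropyl group, or a chain that carries an amine or a carboxylic acid.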